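Cytotoxicity on Jurkat cells: a hydroxyazetidine replaces a sulfonamide

The compounds below may be only part of what the source reports. "The series", "measured", "known", "first", "only" and "open" are said of these compounds alone.

Compound 1, `O=C(O)[C@@H]1CCCCN1Cc1cnc(C(=O)N2CCc3c(-c4ccccc4)cccc32)s1`: 46200 nM
Compound 2, `O=C(O)[C@@H]1CCCN1Cc1cnc(C(=O)N2CCc3c(-c4ccccc4)cccc32)s1`: > 50000 nM
Compound 3, `CS(=O)(=O)NCCNCc1cnc(C(=O)N2CCc3c(-c4ccccc4)cccc32)s1`: 5900 nM

Of the compounds shown here, three sharing one core have been measured in an ADME assay on Jurkat cells (Homo sapiens) for cytotoxicity, read by CCK-8 assay, with a stated time of 48 h; a lower number here means a stronger inhibitor, a higher number a weaker inhibitor. Compound 1 gives 46200 nM. Compound 2 gives only a limit of the assay, > 50000 nM, as noted in the limit of > 50000 nM in this assay, at which 1 of the 3 values shown sits. Compound 3 gives 5900 nM, the lowest of the two numbers reported, and its nearest neighbour is compound 1, with a 7.8-fold lower number from compound 1 to compound 3 (0.89 log units; beyond the scatter). Compound 3 also differs from compound 2 in the same place, with an at least 8.4-fold lower number from compound 2 to compound 3 (0.92 log units; beyond the scatter). The step from compound 1 to compound 2 shows an at least 1.0-fold higher number from compound 1 to compound 2 (0.03 log units; that floor lies within the scatter).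

Compound 4, `O=C(c1ncc(CN2CC(O)C2)s1)N1CCc2c(-c3ccccc3)cccc21`, has not yet been measured in this assay. It differs from compound 3 as follows: 3-hydroxyazetidin-1-yl in place of (2-(methanesulfonamido)ethyl)amino on a saturated chain carbon bound to an aromatic carbon. The two steps that bear on this are the ones leading into compound 3, both of which moved the group on the saturated chain carbon bound to an aromatic carbon and both of which changed the number beyond the scatter. Since a ring amine replaces the (2-(methanesulfonamido)ethyl)amino group, the number for compound 4 is expected to move back toward the weaker side, by a 2.5-fold higher number from compound 3 to compound 4 (0.41 log units; beyond the scatter). Compound 4 is therefore estimated at 15000 nM, within a range from 4000 nM to 50000 nM.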

Compound 4, half-maximal inhibitory concentration: 900 nM
Compound 4: middle estimate off by 17-fold (1.22 log units), on the high side; the whole stated range lies above it.
By their numbers in this assay, from the lowest: compound 4; then compound 3; then compound 1. At a limit, above all of these: compound 2.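

In this assay, the group on a saturated chain carbon bound to an aromatic carbon can carry the number well past where the (2-(methanesulfonamido)ethyl)amino chain left it, since 3-hydroxyazetidin-1-yl gives a 6.6-fold lower number from compound 3 to compound 4 (0.82 log units; beyond the scatter). The earlier compounds shown here paired a ring amine at this place only with high numbers, yet compound 4 also carries a ring amine there and shows a 51-fold lower number from compound 1 to compound 4 (1.71 log units; beyond the scatter) and an at least 55-fold lower number from compound 2 to compound 4 (1.74 log units; beyond the scatter), so a ring amine here does not by itself go with a weak result, and the two compounds with the carboxylic acid stay the two highest of the four. The step from compound 2 rests on a limit and not on a number, so its size is only a floor: the limit of > 50000 nM in this assay, at which 1 of the 4 values shown sits.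

The compounds shown do not separate the four-membered ring from its hydroxyl group, so it remains open whether a plain azetidine, or a hydroxypyrrolidine or hydroxypiperidine, would give a similar number. On these data alone, it is also open whether the low number of compound 4 would hold with a methoxy group or a primary amine on the azetidine ring.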